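A few compounds are considered here, and "the series" means these few. Any claim that something is new, unique, unknown or untested is made for them only; others in the source may bear on it.

Compound 1, `O=S(=O)(c1ccc(F)cc1)c1cnc2cc(Cl)c(F)cc2c1-c1ccc(Cl)cc1`: "not determined" (no result reported).
Compound 2, `O=S(=O)(c1cc(Cl)cc(Cl)c1)c1cnc2c(F)cccc2c1-c1ccc(F)cc1`: 6.8 nM.

Two compounds were made, but only one of them carries a number. In an assay (strain Sprague-Dawley) for displacement of a labelled ligand from metabotropic glutamate receptor 5 (Rattus norvegicus), with a stated time of 60 min (on this read-out higher numbers stand for weaker inhibition and lower numbers for stronger inhibition), compound 2 gives 6.8 nM. Compound 1 has no result in this assay, so compound 2 stands alone as the sole measured point, with nothing to rank it against.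

Compound 3, `O=S(=O)(c1cccc(F)c1)c1cnc2c(F)cccc2c1-c1ccc(F)cc1`, keeps the shared core of compound 2 and changes one group: 3-fluorophenyl in place of 3,5-dichlorophenyl on a sulfonyl sulfur. Within the data shown here, no measured pair differs in only this one place, so the size of the step has no direct precedent here. The expectation is that this change costs some potency, with the step of a 2.9-fold higher number from compound 2 to compound 3 (0.47 log units; beyond the scatter) lying a little beyond the usual scatter, toward weaker inhibition. On that basis compound 3 is estimated to reach 20 nM in this assay, within a range from 6 nM to 70 nM.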

Compound 3, inhibition constant: 31.6 nM
For compound 3 the middle estimate is 1.6-fold (0.20 log units) below the measured one, and the stated range covers the measured number.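

Among these compounds, replacing 3,5-dichlorophenyl with 3-fluorophenyl on the sulfonyl sulfur gives the first measured step at this position: in this assay the change brings a 4.6-fold higher number from compound 2 to compound 3 (0.67 log units; beyond the scatter) and so weaker inhibition. The position is therefore sensitive to the group it carries, although the loss is modest, and compound 3 still gives 31.6 nM with one fluorine on the ring in place of two chlorines. Nothing available here explains why the number moves.

This single pair changes the chlorines and the fluorine together, so it cannot show how much each contributes. It also leaves open how inhibition would respond to a 3-chlorophenyl group on the sulfonyl sulfur, or to a phenyl ring bearing an amine or a carboxylic acid there.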